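Working notes on an unmeasured benzyl analogue of the series

The compounds below may be only part of what the source reports. "The series", "measured", "known", "first", "only" and "open" are said of these compounds alone.

Measured so far:
compound 1 `Cc1ccc(-n2cc(CNC(=O)c3cccc4c3cnn4C(C)C)nn2)cc1C` — > 40000 nM
compound 2 `Cc1cccc(-n2cc(CNC(=O)c3cccc4c3cnn4C(C)C)nn2)c1` — > 40000 nM

In a functional assay on HepG2 cells (Homo sapiens) for inhibition, read by MTT assay, with a stated time of 72 h (on this read-out higher numbers stand for weaker inhibition and lower numbers for stronger inhibition), compound 1 gives > 40000 nM, which is a limit of the assay and not a number. Compound 2 gives > 40000 nM in this assay, again a limit. Within the data shown here, the only measured step, a step that the two limits leave unreadable from compound 1 to compound 2, is therefore unreadable in size; the sole evidence on it is the limit of > 40000 nM in this assay, at which 2 of the 2 values shown sit. Among the measured compounds shown here, compound 2 thus stands at a limit, and the one other value in the set is a limit too, so no reference point with a number exists anywhere.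

Compound 3 `COc1ccc(Cn2cc(CNC(=O)c3cccc4c3cnn4C(C)C)nn2)cc1` differs from compound 2 by 4-methoxybenzyl in place of 3-methylphenyl on an aromatic nitrogen. For the measured compounds named here, no measured step bears on this change in a readable way, so the size and direction of the step in this assay cannot be taken from the data. The expected step of a number no higher from compound 2 to compound 3 (the limit leaves the size open) is therefore set at none beyond the scatter, with the limit remaining the most probable outcome. For compound 3 the estimated value in this assay is 40000 nM, with a range from 8000 nM to 100000 nM.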

Compound 3, half-maximal inhibitory concentration: > 40000 nM
Compound 3: a limit, no number; the forecaster's own chance of this, stated with the estimate: 70%; the middle value sits exactly at the limit.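

Among these compounds, the steps among compound 1, compound 2 and compound 3 cannot be read in this assay; the only evidence is a limit of the assay and not a number: the limit of > 40000 nM in this assay, at which 3 of the 3 values shown sit. The compounds shown leave open whether any group on the aromatic nitrogen, or any change to the shared core, would give a measurable number in this assay.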